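A few compounds are considered here, and "the series" means these few. Any claim that something is new, unique, unknown or untested is made for them only; others in the source may bear on it.

Compound 1 `C=CCCC(=O)N[C@H]1[C@@H](OCCCCCCCCCCCCCCCC)O[C@H](CO)[C@@H](O)[C@@H]1O` carries a free hydroxy group on its sugar core. In a functional assay on U-373MG ATCC cells (Homo sapiens), read by thymidine incorporation (on this read-out lower numbers stand for stronger inhibition and higher numbers for weaker inhibition), compound 1 gives only a limit, > 50 uM; the value the limit of > 50 uM in this assay, at which 1 of the 3 values shown sits, is a limit of the assay rather than a number. Compound 3 `CCCCCCCCCCCCCCCCO[C@H]1O[C@H](COCC(CO)(CO)CO)[C@@H](O)[C@H](O)[C@H]1NC(=O)CCCC` has a different core, and the difference between the two cores is not broken down here. In this assay compound 3 gives 27.3 uM. Compound 2 `CCCCCCCCCCCCCCCCO[C@H]1O[C@H](COCC(CO)(CO)COS(=O)(=O)O)[C@@H](O)[C@H](O)[C@H]1NC(=O)CCCC` differs from compound 3 by sulfo in place of hydrogen on an oxygen on a saturated carbon, and in this assay compound 2 gives 3.2 uM, so the step is an 8.5-fold lower number from compound 3 to compound 2 (0.93 log units; beyond the scatter). Compound 4 `C=CCCC(=O)N[C@H]1[C@@H](OCCCCCCCCCCCCCCCC)O[C@H](CO)[C@@H](O)[C@@H]1OS(=O)(=O)O` differs from compound 1 by sulfo in place of hydrogen on an oxygen on a saturated carbon. This is the same kind of change, though here the oxygen sits on a saturated carbon whose other neighbour is a saturated ring carbon, whereas in compound 2 the neighbour is a saturated chain carbon. Because compound 1 shows only the limit (the limit of > 50 uM in this assay, at which 1 of the 3 values shown sits), the starting point is uncertain, and the expected step from compound 1 to compound 4 is estimated at an at least 4.1-fold lower number from compound 1 to compound 4 (0.61 log units; beyond the scatter), guided by the earlier step. Compound 4 is therefore estimated at 12 uM, likely between 3 uM and 50 uM.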

Compound 4, concentration for 50% inhibition: 33 uM
Estimate against measurement, compound 4: 2.8-fold (0.44 log units) below, and the stated range covers the measured number.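

On the core of compound 1, sulfo in place of hydrogen gives an at least 1.5-fold lower number from compound 1 to compound 4 (0.18 log units; that floor lies within the scatter) in this assay, so a real gain is possible there but is not shown. Compound 1 gives > 50 uM, which is a limit of the assay and not a number. The change may therefore carry over to this second core at a similar size or a smaller one, and the data cannot separate the two: the same change on two cores in this assay, an 8.5-fold lower number (0.93 log units; beyond the scatter) from compound 3 to compound 2 and an at least 1.5-fold lower number (0.18 log units; that floor lies within the scatter) from compound 1 to compound 4; the limit leaves it open whether they differ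

The compounds shown leave open whether sulfooxy is the only group that gives such a step. A carboxylic acid or a phosphate in its place could read the same or differently in this assay, on either core.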